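Hydroxyethyl Replaces Hydroxy on a Shared Core

The compounds below may be only part of what the source reports. "The series", "measured", "known", "first", "only" and "open" are said of these compounds alone.

Measured in an ADME assay on Huh-7 cells (Homo sapiens) for cytotoxicity, with a stated time of 3 days; on this read-out lower numbers stand for higher toxicity in this test and higher numbers for lower toxicity in this test:

Compound 1 `COc1ccccc1NC(=O)c1c(NO)cc(-c2ccccc2)oc1=O` gives > 20000 nM, a limit of the assay rather than a number.
Compound 2 `CCOc1ccccc1NC(=O)c1c(NO)cc(-c2ccccc2)oc1=O` gives > 20000 nM, also a limit.
Compound 3 `Nc1ccccc1NC(=O)c1c(NO)cc(-c2ccccc2)oc1=O` gives > 20000 nM, again a limit.

The three measured compounds share one core and differ only in the group carried on the outer aromatic ring. Among the compounds with values here, compound 2 stands exactly where the others stand, at the limit of > 20000 nM in this assay, at which 3 of the 3 values shown sit; no measured compound sits apart from the rest. Because every value is a limit, the single-place steps between them cannot be read: a step that the two limits leave unreadable from compound 1 to compound 2, a step that the two limits leave unreadable from compound 1 to compound 3 and a step that the two limits leave unreadable from compound 2 to compound 3.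

Compound 4 `CCOc1ccccc1NC(=O)c1c(NCCO)cc(-c2ccccc2)oc1=O` differs from compound 2 in a different place, (2-hydroxyethyl in place of hydroxy on a nitrogen on an aromatic ring). Within the data shown here, none of the measured steps touches that nitrogen; they all concern the group on the outer ring, so no measured step speaks directly to this change. What can be said is that every measured compound, whatever its outer group, sits at the limit.

In this assay the step is therefore expected to be a step that the limit leaves unreadable from compound 2 to compound 4, without a readable size. Compound 4 is expected to give 30000 nM, within a range from 10000 nM to 100000 nM, and most likely to be reported once more as a limit rather than a number.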

Compound 4, half-maximal cytotoxic concentration: > 20000 nM
Compound 4: only a limit was reported; the forecaster's own chance of this, stated with the estimate: 85%; the middle value is on the limit's open side.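

In this assay compound 4 gives > 20000 nM, which is a limit of the assay and not a number. Compound 2 and compound 4 both stand at limits, so no new step can be read between them. The compounds shown leave open what concentration would actually prove toxic to these cells, and whether 2-hydroxyethyl in place of hydroxy changes it, with all values at one shared limit: the limit of > 20000 nM in this assay, at which 4 of the 4 values shown sit.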